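Methyl on the phenyl ring: an expected small step

This account rests on a few compounds, and the source may have more. Where it says the series, first, only, none or still open, it means among the compounds named here.

Compound 1 `S=c1[nH]nc(-c2ccccc2)n1CCSCc1ccccc1` is measured in a functional assay on HeLa cells (Homo sapiens) for cytotoxicity, read by LDH release, with a stated time of 24 h (on this read-out higher numbers stand for weaker inhibition and lower numbers for stronger inhibition), where compound 1 gives 152000 nM. Compound 2 `Fc1ccccc1CSCCn1c(-c2ccccc2)n[nH]c1=S` carries fluoro in place of hydrogen on an aromatic carbon, and in this assay compound 2 gives 165000 nM; the step of a 1.1-fold higher number from compound 1 to compound 2 (0.04 log units; within the scatter) is within the scatter, so the two numbers cannot be told apart. Compound 3 `O=[N+]([O-])c1ccc(O)c(CSCCn2c(-c3ccccc3)n[nH]c2=S)c1` gives only a limit of the assay, > 250000 nM, and no number; this is the limit of > 250000 nM in this assay, at which 1 of the 3 values shown sits. Compound 1 therefore stands among the two numbers that were read, with compound 2 beside it within the scatter, while compound 3 sits at the limit.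

Compound 4 `Cc1ccccc1-c1n[nH]c(=S)n1CCSCc1ccccc1` differs from compound 1 by methyl in place of hydrogen on an aromatic carbon. Among the compounds with values here, the only measured step that bears on a small substituent added to an aromatic carbon is the one from compound 1 to compound 2, and it was within the scatter. A change of similar size is therefore expected for compound 4, with no step beyond the scatter in either direction: the estimate is a 1.1-fold higher number from compound 1 to compound 4 (0.02 log units; within the scatter). Compound 4 is expected to give 160000 nM in this assay, within a range from 80000 nM to 320000 nM.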

Compound 4, half-maximal inhibitory concentration: 121000 nM
For compound 4 the middle estimate is 1.3-fold (0.12 log units) above the measured one; low and high end bracket the measured number.
By their numbers in this assay, from the lowest: compounds 4, 1 and 2 (each within the scatter of the next). At a limit, above all of these: compound 3.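

Compound 1 to compound 4 is the first step shown at this place, phenyl to 2-methylphenyl, with the methyl ortho to a large group; the one readable earlier step, the fluoro change, lay on a different aromatic ring. In this assay the step is a 1.3-fold lower number from compound 1 to compound 4 (0.10 log units; within the scatter) and so lies within the scatter, which means that this added methyl gives no readable difference between the two compounds. Nothing at hand bears on why this change leaves the two numbers indistinguishable.

Going by these compounds, whether an ethyl group, an amine or a carboxylic acid at this same place would give a step beyond the scatter remains open. So does the outcome of a methyl placed elsewhere on this phenyl ring.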